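Benzimidazole ureas and thioureas: swapping the benzyl substituent

The source may hold more compounds than are shown below. What is called first, only, known or untested is meant among the compounds shown, and "the series" means these compounds.

Compound 1 `Cc1ccc(NC(=S)NC(=O)c2ccc(OCc3cccc(Cl)c3Cl)cc2)cc1-c1nc2ccccc2[nH]1` gives, in a functional assay on MGC-803 cells (Homo sapiens) for inhibition, read by MTT assay, with a stated time of 48 h (on this read-out higher numbers stand for weaker inhibition and lower numbers for stronger inhibition), only the limit > 100000 nM. Compound 2 `Cc1ccc(COc2ccc(C(=O)NC(=S)Nc3ccc(C)c(-c4nc5ccccc5[nH]4)c3)cc2)cc1` gives 4980 nM. Compound 3 `Cc1ccc(NC(=O)NC(=O)c2ccc(OCc3ccc(C(F)(F)F)cc3)cc2)cc1-c1nc2ccccc2[nH]1` gives 14900 nM.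

Compound 3 therefore holds the highest of the two numbers, with compound 2 next, a gap beyond the scatter. Compound 4 `Cc1ccc(NC(=O)NC(=O)c2ccc(OCc3ccccc3Cl)cc2)cc1-c1nc2ccccc2[nH]1` differs from compound 3 by 2-chlorophenyl in place of 4-(trifluoromethyl)phenyl on a saturated chain carbon bound to an oxygen on an aromatic ring. Going by the values given here, the only measured step at that position is an at least 20-fold lower number from compound 1 to compound 2 (1.30 log units; beyond the scatter), where the 2,3-dichlorophenyl partner sits at the limit of > 100000 nM in this assay, at which 1 of the 3 values shown sits, and the 4-methylphenyl partner gives a number. From the compounds shown here alone, that step runs in the opposite sense to the change here, so a modestly higher number is expected for compound 4, though the urea of compound 3 is untested in this respect. Compound 4 is estimated at 25000 nM, between 8000 nM and 80000 nM, an expected step of a 1.7-fold higher number from compound 3 to compound 4 (0.22 log units; within the scatter).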

Compound 4, half-maximal inhibitory concentration: 19500 nM
Compound 4: the middle estimate sits 1.3-fold (0.11 log units) above what was measured, and the stated range covers the measured number.
By their numbers in this assay, from the lowest: compound 2; then compounds 3 and 4 (each within the scatter of the next). At a limit, above all of these: compound 1.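

In this assay, this position now has a step with a number at both ends, a 1.3-fold higher number from compound 3 to compound 4 (0.12 log units; within the scatter), so exchanging 4-(trifluoromethyl)phenyl for 2-chlorophenyl on the urea compounds gives no change that can be told from scatter. The position therefore does not give a large step with every exchange. The earlier large step was also open-ended, with compound 1 at a limit: the limit of > 100000 nM in this assay, at which 1 of the 4 values shown sits.

From the compounds shown here alone, whether these two groups would also match on a thiourea remains open. So does what an amine or a carboxylic acid would give in their place.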